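Bromophenyl for Nitrophenyl, Judged Against Mouse Fibroblast Toxicity

This account rests on a few compounds, and the source may have more. Where it says the series, first, only, none or still open, it means among the compounds named here.

Compound 1, `CN(C)c1ccc(NCc2cncn2Cc2ccc(-c3ccccc3)cc2)cc1-c1ccccc1`, gives > 1000 nM in a toxicity assay on NIH3T3 cells (Mus musculus) for cytotoxicity, read by resazurin assay; on this read-out lower numbers stand for an effect already at smaller amounts and higher numbers for an effect only at larger amounts of compound.
Compound 2, `COC(=O)c1ccc(NCc2cncn2Cc2cccc([N+](=O)[O-])c2)cc1-c1ccccc1`, gives > 10000 nM in this assay.
Compound 3, `Cc1ccccc1-c1cc(NCc2cncn2Cc2ccc(-c3ccccc3)cc2)ccc1-c1nc2ccccc2s1`, gives > 1000 nM in this assay.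

Every value shown here is a limit of this assay and not a number. Compound 2 stands at the limit of > 10000 nM in this assay, at which 1 of the 3 values shown sits. The two other compounds stand at the limit of > 1000 nM in this assay, at which 2 of the 3 values shown sit. Among the compounds with values here, no pair of the measured compounds differs in a single place, so no measured step is available, and nothing in the three values speaks for a shift in either direction once a limit is reached.

Compound 4, `COC(=O)c1ccc(NCc2cncn2Cc2ccc(Br)cc2)cc1-c1ccccc1`, has not yet been measured in this assay. It differs from compound 2 in one place: 4-bromophenyl in place of 3-nitrophenyl on a saturated chain carbon bound to an aromatic nitrogen. With only limits to go on, the expectation for compound 4 is that it also sits at a limit rather than a number, and its value is estimated at 10000 nM, with a range from 3000 nM to 30000 nM. The step this estimate means, a number no higher from compound 2 to compound 4 (the limit leaves the size open), is expected to be none beyond the scatter, with no direction claimed.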

Compound 4, half-maximal effective concentration: > 10000 nM
Compound 4: a limit, no number; the forecaster's own chance of this, stated with the estimate: 80%; the middle value lies on the limit itself.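

In this assay compound 4 gives > 10000 nM, which is a limit and not a number. Compound 2 stands at the same limit, so no step can be read between the two compounds: the limit of > 10000 nM in this assay, at which 2 of the 4 values shown sit.

The compounds shown leave open whether 4-bromophenyl in place of 3-nitrophenyl changes the concentration at which an effect would appear.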